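This account rests on a few compounds, and the source may have more. Where it says the series, first, only, none or still open, it means among the compounds named here.

Measured in a functional assay on MDA-MB-231 cells (Homo sapiens) for inhibition, read by sulforhodamine B assay; a higher number here means a weaker inhibitor of growth, a lower number a stronger inhibitor of growth:
- compound 1 `COc1cccc(CN2CCC=C(CCC(=O)NO)C2=O)c1`: 3920 nM
- compound 2 `Cc1ccc(CN2CCC=C(CCC(=O)NO)C2=O)cc1`: 1430 nM

Of these two measured compounds, compound 2 at 1430 nM has the lower number and so is the stronger inhibitor of growth. Compound 1 gives 3920 nM, and its gap from compound 2 lies beyond the scatter of repeated measurements.

The next compound to be tested is compound 3 `Cc1cccc(CN2CCC=C(CCC(=O)NO)C2=O)c1`, which has the same atoms as compound 2, joined differently. In 3-methylphenyl in place of 4-methylphenyl on a saturated chain carbon bound to an amide-type nitrogen in a ring the change is 3-methylphenyl in place of 4-methylphenyl, on a saturated chain carbon bound to an amide-type nitrogen in a ring. The measured compounds offer no direct comparison of these two groups, so the expectation rests on just two values in this assay and remains loose.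

The expected result is a 1.5-fold higher number from compound 2 to compound 3 (0.17 log units; within the scatter), a small rise in the number that is not expected to pass beyond the scatter. For compound 3 the estimated value is 2100 nM, with an expected range from 1000 nM to 4500 nM.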

Compound 3, concentration for 50% growth inhibition: 8120 nM
For compound 3 the middle estimate is 3.9-fold (0.59 log units) below the measured one; the measured number lies above the stated range.
By their numbers in this assay, from the lowest: compound 2; then compound 1; then compound 3.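

In this assay, 3-methylphenyl in place of 4-methylphenyl, on a saturated chain carbon bound to an amide-type nitrogen in a ring, gives a 5.7-fold higher number from compound 2 to compound 3 (0.75 log units; beyond the scatter), so growth inhibition at this place depends on how the methyl group is attached to the aromatic ring, even though the two groups have the same atoms. Methyl in place of methoxy on an aromatic carbon gives a 2.1-fold higher number from compound 1 to compound 3 (0.32 log units; beyond the scatter), which shows that methyl is not the better of these two groups in every arrangement and leaves compound 3 as the weakest inhibitor of growth among the three compounds. No measurement is available here that accounts for either step.

Among these compounds, only one pair of compounds compares 3-methylphenyl and 4-methylphenyl, so it remains open whether 4-methoxyphenyl would likewise give a lower number than the 3-methoxyphenyl group of compound 1. The compounds shown also leave open how 2-methylphenyl or an unsubstituted phenyl group would compare at the same place, and so whether 4-methylphenyl stands out from a wider set of groups.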